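Notes on the step from compound 2 to compound 3

A few compounds are considered here, and "the series" means these few. Any claim that something is new, unique, unknown or untested is made for them only; others in the source may bear on it.

Of the compounds shown here, two have been measured so far in a functional assay on A549 cells (Homo sapiens) for inhibition, read by CCK-8 assay, with a stated time of 72 h, tested at 10 uM (on this read-out higher numbers stand for more inhibition of growth at the one concentration tested and lower numbers for less inhibition of growth), and both sit high on the read-out. Compound 1 (`Cc1cccc(NC(=O)C2(C(=O)Nc3ccc(Nc4ncc5cc(C(=O)N(C)C)n(C6CCCC6)c5n4)cc3)CC2)c1`) gives 86.1% and compound 2 (`CN(C)C(=O)c1cc2cnc(Nc3ccc(NC(=O)C4(C(=O)Nc5cccc(Br)c5)CC4)cc3)nc2n1C1CCCC1`) gives 92.2% and the two lie within the scatter of each other. The next structure is compound 3 (`CN(C)C(=O)c1cc2cnc(Nc3ccc(NC(=O)C4(C(=O)Nc5ccc(C#N)cc5)CC4)cc3)nc2n1C1CCCC1`), which has 4-cyanophenyl in place of 3-bromophenyl on an amide-type nitrogen. Within the data shown here, only one measured step bears on this change, the swap of methyl for bromo on an aromatic carbon of the same aryl group, and it reads a number 6.1 percentage points higher from compound 1 to compound 2 (within the scatter) with no shift beyond the scatter. On the strength of that single small step, no move beyond the scatter is expected in this assay for the new change. Among the measured compounds shown here, the guide is thin, since no measured compound carries a nitrile or the 4-cyanophenyl group, so the range is kept wide. The estimated step is a number 6.2 percentage points lower from compound 2 to compound 3 (within the scatter) and lies slightly downward. Compound 3 is expected at 86% (estimated range 70% to 97%).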

Compound 3, percent growth inhibition at one concentration: 95%
Estimate against measurement, compound 3: 9 percentage points below; low and high end bracket the measured number.
By their numbers in this assay, from the lowest: compounds 1, 2 and 3 (each within the scatter of the next).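

In this assay, the amide-type nitrogen carries 4-cyanophenyl as readily as the earlier aryl groups: the reading is a number 2.8 percentage points higher from compound 2 to compound 3 (within the scatter) and a number 8.9 percentage points higher from compound 1 to compound 3 (within the scatter) on the same read-out. The earlier pair showed only that methyl and bromo are interchangeable on a 3-substituted phenyl ring, whereas this result extends that to a different substituent at a different printed ring place, a nitrile that brings one triple bond and one hydrogen-bond acceptor, with no change beyond the scatter. No measurement on hand accounts for this reading.

Because group and ring place change together in this step, their separate contributions stay unresolved, and 3-cyanophenyl or 4-bromophenyl on the same nitrogen would be needed to separate them. Also open, as far as these compounds go, are whether a phenyl ring bearing a carboxylic acid or a primary amine would stay in this range, and whether the three compounds, all high at the one concentration tested, would separate at lower concentrations.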